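Three tetrahydropyran alcohols and a repositioned methoxy group

The source may report more compounds than this note shows. Statements on the series, on what has been measured and on what is new or still open speak of the compounds shown alone.

Measured so far in a functional assay on HeLa cells (Homo sapiens) for cytotoxicity, read by WST assay, with a stated time of 48 h; on this read-out lower numbers stand for stronger inhibition and higher numbers for weaker inhibition:
- compound 1 `COc1ccc(/C=C/C[C@H]2C[C@@H]([C@@H](O)c3ccccc3)CO[C@@H]2c2ccccc2)cc1`: 8300 nM
- compound 2 `COc1ccc(/C=C/C[C@@H]2C[C@@H]([C@@H](O)c3ccc(OC)c(OC)c3)CO[C@H]2c2ccc(OC)c(OC)c2)cc1OC`: 30600 nM
- compound 3 `COc1ccc([C@H](O)[C@H]2CO[C@H](c3ccc(OC)c(OC)c3)[C@@H](C/C=C/c3ccc(OC)c(OC)c3)C2)cc1`: 46000 nM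

Compound 1 gives the lowest number of the three in this assay. Compound 2 and compound 3 both return higher numbers, and both of those gaps lie beyond the scatter of repeated measurements, so compound 1 stands apart as the most active of the set. Going by the values given here, no pair of the measured compounds differs in only one place, so no single-point step is available to lean on.

Compound 4 `COc1ccccc1/C=C/C[C@H]1C[C@@H]([C@@H](O)c2ccccc2)CO[C@@H]1c1ccccc1` is built from the same atoms as compound 1, joined differently: 2-methoxyphenyl in place of 4-methoxyphenyl on a double-bonded chain carbon bound to a double-bonded chain carbon. Nothing in the measured set isolates the effect of moving the methoxy group on the aryl ring of the chain, so the direction of the change is open. The expectation is a small step, if any, and the value is taken to stay close to that of compound 1. The step of a 1.2-fold higher number from compound 1 to compound 4 (0.08 log units; within the scatter) is expected to fall within the scatter. Compound 4 is therefore estimated at 10000 nM, with a range from 4000 nM to 25000 nM.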

Compound 4, half-maximal inhibitory concentration: 14700 nM
Estimate against measurement, compound 4: 1.5-fold (0.17 log units) below; the range from low to high includes it.
By their numbers in this assay, from the lowest: compounds 1 and 4 (each within the scatter of the next); then compounds 2 and 3 (each within the scatter of the next).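

In this assay the series now has its first change in a single place: 2-methoxyphenyl in place of 4-methoxyphenyl on a double-bonded chain carbon bound to a double-bonded chain carbon gives a 1.8-fold higher number from compound 1 to compound 4 (0.25 log units; within the scatter) and so leaves the two values indistinguishable. Going by these compounds alone, the methoxy group on this aryl ring can therefore sit at either of these two ring positions without a change that can be read in this assay, something the earlier compounds, which differ in several places at once, could not show. No measurement bears on why this is so.

From the compounds shown here alone, whether this tolerance extends to a different group at the same place, such as an amine or a carboxylic acid on the aryl ring, stays open. Compound 2 and compound 3 still differ from these two compounds in more than one place, so the contribution of each of their extra methoxy groups cannot be read.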